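This account rests on a few compounds, and the source may have more. Where it says the series, first, only, none or still open, it means among the compounds named here.

Working notes on the series. Among the compounds with values here, in an ADME assay on L6 cells (Rattus norvegicus) for cytotoxicity (a higher number here means a weaker inhibitor, a lower number a stronger inhibitor), compound 3 (`CCN(CC)CCC(=O)OC1CC2(N(C)C)CC(c3ccccc3)C1C(c1ccccc1)C2`) gives 23600 nM, the only single number among the measured compounds. Compound 1 (`O=C(CN1CCCC1)OC1CC2(N3CCCCC3)CC(c3ccccc3)C1C(c1ccccc1)C2`) carries piperidin-1-yl with another ester group and gives 16400 nM; 52000 nM (2 entries), so its entries are widely spread. Compound 2 (`O=C(CN1CCCCC1)OC1CC2(N3CCCCC3)CC(c3ccccc3)C1C(c1ccccc1)C2`) also carries piperidin-1-yl with another ester group and gives 60400 nM; > 184000 nM (2 entries). The second entry of compound 2 is a limit of this assay and not a number.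

Compound 4 (`CCN(CC)CCC(=O)OC1CC2(N3CCCCC3)CC(c3ccccc3)C1C(c1ccccc1)C2`) keeps the ((2-(diethylamino)ethyl)carbonyl)oxy group of compound 3 and has piperidin-1-yl in place of dimethylamino on a saturated ring carbon. Within the data shown here, no measured pair isolates this change, so the expectation is loose. Among the measured compounds shown here, the single value of compound 3, 23600 nM, falls inside the span of compound 1, 16400 nM; 52000 nM (2 entries). No step beyond the scatter is therefore expected in this assay, and the estimate is a 1.3-fold higher number from compound 3 to compound 4 (0.10 log units; within the scatter). For compound 4 the estimated value is 30000 nM, with an expected range from 11000 nM to 85000 nM.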

Compound 4, half-maximal inhibitory concentration: 22900 nM
For compound 4 the middle estimate is 1.3-fold (0.12 log units) above the measured one; the measured number falls inside the stated range.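

In this assay, the first pair differing in one place gives a 1.0-fold lower number from compound 3 to compound 4 (0.01 log units; within the scatter). Within the data shown here, with the ((2-(diethylamino)ethyl)carbonyl)oxy group held constant, piperidin-1-yl in place of dimethylamino on this saturated ring carbon therefore leaves the read-out without a discernible difference, which the earlier compounds could not show because none of them formed such a pair. A step this small is also far narrower than the spread between repeated entries for a single compound: the several entries of compound 1 in this assay, 16400 nM; 52000 nM (2 entries)

Among these compounds, this result covers only one ester group, so it remains open whether the same exchange would read alike with the ester groups of compound 1 and compound 2. As far as these compounds go, it also remains open how a morpholin-4-yl group or a primary amine on this carbon would read.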